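The source may hold more compounds than are shown below. What is called first, only, known or untested is meant among the compounds shown, and "the series" means these compounds.

Measured compounds so far:

Compound 1, `COc1ccc(-c2cc(=O)c3c(OC)cc(OC)cc3n2S(=O)(=O)c2ccc(C=O)cc2)cc1`, in a functional assay on SUP-B15 cells (Homo sapiens) for antiproliferative activity, with a stated time of 72 h (a lower number here means that less compound is needed, a higher number that more compound is needed for the effect), gives > 34400 nM; this is a limit of the assay, not a number.

Compound 2, `COc1ccc(-c2cc(=O)c3c(OC)cc(OC)cc3n2S(=O)(=O)c2ccc(Cl)cc2)cc1`, in this assay gives > 34400 nM, again a limit rather than a number.

Compound 3, `COc1ccc(-c2cc(=O)c3c(OC)cc(OC)cc3n2S(=O)(=O)c2cccc(Br)c2)cc1`, in this assay gives > 58600 nM, also a limit.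

Compound 3 therefore stands at a limit, and the two other values shown are limits as well, so the numbers do not place any of the three compounds above or below another. The change to compound 4, `COc1ccc(-c2cc(=O)c3c(OC)cc(OC)cc3n2S(=O)(=O)Cc2ccccc2)cc1`, is benzyl in place of 3-bromophenyl on a sulfonyl sulfur. The measured steps that touch the same sulfonyl substituent are a step that the two limits leave unreadable from compound 1 to compound 3 and a step that the two limits leave unreadable from compound 2 to compound 3, and the remaining step, a step that the two limits leave unreadable from compound 1 to compound 2, is no more readable. What the data do show is the limit of > 34400 nM in this assay, at which 2 of the 3 values shown sit, and (the limit of > 58600 nM in this assay, at which 1 of the 3 values shown sits). With every measured step unreadable, no direction and no size can be expected for the step to compound 4 beyond the scatter, and the most likely outcome is that compound 4 again returns a limit. Compound 4 is estimated at 58600 nM, with a range from 20000 nM to 200000 nM. The step of a number no higher from compound 3 to compound 4 (the limit leaves the size open) is expected to be essentially none.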

Compound 4, half-maximal effective concentration: > 34400 nM
Compound 4: no number, only a limit (the forecaster's own chance of this, stated with the estimate: 85%); the middle value does not contradict the limit.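

In this assay compound 4 gives > 34400 nM, which is a limit and not a number. None of the steps from compound 1, compound 2 or compound 3 to compound 4 can be read. The compounds shown leave open whether any of these groups on the sulfonyl sulfur changes the concentration needed for antiproliferative activity, and by how much.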